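Swapping a Branched Alkyl Chain for a Thioether on a Pyrazine Core

The source may hold more compounds than are shown below. What is called first, only, known or untested is meant among the compounds shown, and "the series" means these compounds.

Measured compounds:
compound 1 `CCc1nc(NC(CC)CC)c(OC)nc1-c1ccc(OC(F)F)cc1Cl` gives 1.4 nM
compound 2 `CCC(CC)Nc1nc(C)c(-c2ccc(Cl)cc2Cl)nc1C` gives 27 nM
compound 3 `CCc1nc(-c2ccc(Cl)cc2Cl)c(CC)nc1CC(CC)CC` gives 68 nM

Of the compounds shown here, three have been measured in an assay on IMR-32 cells for displacement of a labelled ligand from corticotropin-releasing factor receptor 1 (Homo sapiens), read by scintillation counting, with a stated time of 2 h; a higher number here means a weaker inhibitor, a lower number a stronger inhibitor. All three carry the same kind of six-membered ring with two nitrogens, substituted with a dichlorophenyl or difluoromethoxy-chlorophenyl group and short side chains. Compound 1 gives the lowest number and is the strongest binder of the set. Compound 3 stands at the other end: its number is the highest of the three, and its steps to both compound 2 and compound 1 lie beyond the scatter of repeated measurements, so compound 3 is the weakest binder so far.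

Compound 4 `CCc1nc(-c2ccc(Cl)cc2Cl)c(CC)nc1SC(C)CC` has not yet been measured. It differs from compound 3 in one place: (sec-butyl)sulfanyl in place of 2-ethylbutyl on an aromatic carbon. The branched carbon chain is replaced by a shorter chain attached through a sulfur atom. Among the compounds with values here, no measured pair in this set isolates such a change, so there is no directly comparable step to lean on.

Given that compound 3 has the highest number among the measured compounds, there is more room for the number to fall than to rise, but the evidence is thin. The expectation is a modest step in a 1.7-fold lower number from compound 3 to compound 4 (0.23 log units; within the scatter), towards a somewhat lower number. Compound 4 is estimated to give 40 nM, with a range from 10 nM to 160 nM.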

Compound 4, inhibition constant: 401 nM
Compound 4: middle estimate off by 10-fold (1.00 log units), on the low side; the whole stated range lies below it.
By their numbers in this assay, from the lowest: compound 1; then compound 2; then compound 3; then compound 4.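

In this assay, the change at this aromatic carbon, para to a 2,4-dichlorophenyl group, gives a 5.9-fold higher number from compound 3 to compound 4 (0.77 log units; beyond the scatter), so here (sec-butyl)sulfanyl is no equal of 2-ethylbutyl and binding is weaker with it. Within the data shown here, the earlier compounds differed from one another in more than one place and could not show this; the new pair is the first to isolate a single position, and it shows that the number responds clearly at that position even though the heavy-atom count only moves from 6 to 5. Nothing measured here explains this loss of binding.

As far as these compounds go, the pair changes the linking atom, the chain length and the place of the branch all at once, so it remains open which of these matters. A sec-butoxy group, with oxygen in place of the sulfur, a straight butyl chain on sulfur, or a sulfone at the same carbon would each help to separate these features and show whether any sulfur-linked group can do as well as 2-ethylbutyl here.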